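The compounds below may be only part of what the source reports. "The series", "measured", "known", "first", "only" and "open" are said of these compounds alone.

Measured in a functional assay on COLO 205 cells (Homo sapiens) for inhibition, read by sulforhodamine B assay, with a stated time of 48 h, tested at 50 uM; a higher number here means more inhibition of growth at the concentration tested, a lower number less inhibition of growth:
compound 1 `COc1cc(/C=C/C(=O)/C=C/c2ccco2)ccc1OCc1cn(CCCOc2cc(=O)oc3ccccc23)nn1`: 59%
compound 2 `COc1cccc(/C=C/C(=O)/C=C/c2ccc(OCc3cn(CCCOc4cc(=O)oc5ccccc45)nn3)c(OC)c2)c1`: 52%
compound 3 `COc1cc(/C=C/C(=O)/C=C/c2cccs2)ccc1OCc1cn(CCCOc2cc(=O)oc3ccccc23)nn1`: 55%

Compound 3 stands second highest of the three numbers; its nearest neighbour is compound 2 and its furthest compound 1, both gaps within the scatter (a number 3 percentage points higher from compound 2 to compound 3 (within the scatter); a number 4 percentage points lower from compound 1 to compound 3 (within the scatter)). Compound 4 `COc1ccc(/C=C/C(=O)/C=C/c2ccc(OCc3cn(CCCOc4cc(=O)oc5ccccc45)nn3)c(OC)c2)cc1` differs from compound 3 by 4-methoxyphenyl in place of thiophen-2-yl on a double-bonded chain carbon bound to a double-bonded chain carbon. Among the compounds with values here, the steps that bear on this exchange are the ones between the aryl and heteroaryl groups already seen: a number 7 percentage points lower from compound 1 to compound 2 (within the scatter) and a number 3 percentage points higher from compound 2 to compound 3 (within the scatter). Neither of them exceeded the scatter, so for compound 4 no step beyond the scatter is expected in this assay, in either direction. Compound 4 is therefore estimated at 53%, range 40% to 66%. The expected step from compound 3 is a number 2 percentage points lower from compound 3 to compound 4 (within the scatter).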

Compound 4, percent growth inhibition at one concentration: 53%
Beside the measured number, compound 4's estimate shows no gap at the digits printed; the measured number falls inside the stated range.
By their numbers in this assay, from the lowest: compounds 2, 4, 3 and 1 (each within the scatter of the next).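

In this assay, the 4-methoxyphenyl group adds a further aromatic ring at this position without a step beyond the scatter: a number 2 percentage points lower from compound 3 to compound 4 (within the scatter); a number 1 percentage points higher from compound 2 to compound 4 (within the scatter); a number 6 percentage points lower from compound 1 to compound 4 (within the scatter). The second of these steps also shows that 3-methoxyphenyl and 4-methoxyphenyl cannot be told apart here, so all four groups on this double-bonded chain carbon read alike. No measurement offered here accounts for this flat result. Going by these compounds, whether a dimethylamino group, a carboxylic acid or a longer chain at this place would give a step beyond the scatter remains open.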